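This account rests on a few compounds, and the source may have more. Where it says the series, first, only, none or still open, it means among the compounds named here.

Readings so far in a functional assay on SGC-7901 cells (Homo sapiens) for cytotoxicity, read by MTT assay, with a stated time of 48 h; a higher number here means a weaker inhibitor, a lower number a stronger inhibitor
compound 1 `O=c1cc(-c2ccccc2)oc2cc(OCc3ccc(Cl)nc3)cc(O)c12` gives "not active" (no number reported)
compound 2 `O=c1cc(-c2ccc(OCc3ccc(Cl)nc3)cc2)oc2cc(O)cc(O)c12` gives 25.9 ug/mL

For the measured compounds named here, compound 2, at 25.9 ug/mL, holds the only number, and the one further entry, compound 1, has none. The next compound, compound 3 `O=c1cc(-c2ccc(OCc3ccc(Cl)nc3)cc2)oc2cc(OCc3ccc(Cl)nc3)cc(O)c12`, differs from compound 2 by (6-chloropyridin-3-yl)methyl in place of hydrogen on an oxygen on an aromatic ring, which reads as hydroxy to (6-chloropyridin-3-yl)methoxy. Going by the values given here, no step between measured compounds is available to size this change, so the expectation rests on thin ground. Among the compounds with values here, the only other reading is compound 1 at "not active" (no number reported), and it leans the expectation towards weaker inhibition rather than stronger. The expected move is a 2.1-fold higher number from compound 2 to compound 3 (0.33 log units; beyond the scatter) as an estimate with wide uncertainty. In this assay compound 3 is estimated at 55 ug/mL with an expected range of 20 ug/mL to 130 ug/mL and a real chance of no number at all.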

Compound 3, half-maximal inhibitory concentration: 22.3 ug/mL
For compound 3 the middle estimate is 2.5-fold (0.39 log units) above the measured one, and the stated range covers the measured number.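

In this assay, (6-chloropyridin-3-yl)methyl in place of hydrogen on this oxygen gives a 1.2-fold lower number from compound 2 to compound 3 (0.06 log units; within the scatter), so this position accepts hydroxy to (6-chloropyridin-3-yl)methoxy with no shift in the read-out beyond the scatter. The entering group brings a whole six-membered aromatic ring, yet a number remains, something the earlier reading of compound 1 at "not active" (no number reported) gave no hint of. No measurement at hand explains why the read-out holds.

Open, from the compounds shown here alone, is whether the flat response at this oxygen extends to other groups there, such as a plain methyl, a 2-aminoethyl chain or a carboxylic acid on a short chain. Also open, going by these compounds, is whether any group at this position can move the number beyond the scatter in either direction.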